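Changing the aromatic group of compound 3

A few compounds are considered here, and "the series" means these few. Any claim that something is new, unique, unknown or untested is made for them only; others in the source may bear on it.

In an ADME assay on J774 cells (Mus musculus) for antiproliferative activity, with a stated time of 72 h (on this read-out lower numbers stand for an effect already at smaller amounts and higher numbers for an effect only at larger amounts of compound), compound 1 `CCCCc1cc2c(=O)c(CC)c(C)[nH]c2cc1OCCOc1ccccc1` gives 1000 nM with ethyl on the shared core. Compound 2 `CCCCc1cc2c(=O)c(-c3ccccc3)c(C)[nH]c2cc1OCCOc1ccccc1` gives 23000 nM with phenyl at that place, and compound 3 `CCCCc1cc2c(=O)c(-c3ccc(OC(F)(F)F)cc3)c(C)[nH]c2cc1OCCOc1ccccc1` gives 20000 nM with 4-(trifluoromethoxy)phenyl there. Compound 3 thus lies within the scatter of compound 2 and far from compound 1. The steps of a 23-fold higher number from compound 1 to compound 2 (1.36 log units; beyond the scatter) and a 20-fold higher number from compound 1 to compound 3 (1.30 log units; beyond the scatter) are both large, while a 1.2-fold lower number from compound 2 to compound 3 (0.06 log units; within the scatter) stays within the scatter.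

Compound 4 `CCCCc1cc2c(=O)c(-c3ccc(C(F)(F)F)cc3C)c(C)[nH]c2cc1OCCOc1ccccc1` carries 2-methyl-4-(trifluoromethyl)phenyl in place of 4-(trifluoromethoxy)phenyl on an aromatic carbon at the same place on the core. This swap keeps a substituted phenyl ring there, so the closest guide is the small step of a 1.2-fold lower number from compound 2 to compound 3 (0.06 log units; within the scatter) and not the two large ones. Among the compounds with values here, no measured compound has a methyl on this ring, so that part remains untested. The expected change in this assay is a 1.1-fold lower number from compound 3 to compound 4 (0.05 log units; within the scatter) and stays within the scatter. For compound 4 the estimate is 18000 nM and the expected range of 7000 nM to 40000 nM allows for the untested methyl.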

Compound 4, half-maximal effective concentration: 20000 nM
The estimate for compound 4 lay 1.1-fold (0.05 log units) below the measured number; the measured number falls inside the stated range.
By their numbers in this assay, from the lowest: compound 1; then compounds 3, 4 and 2 (each within the scatter of the next).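

In this assay the new ring gives no change at the digits printed from compound 3 to compound 4 (within the scatter) and a 1.2-fold lower number from compound 2 to compound 4 (0.06 log units; within the scatter) with a methyl added and trifluoromethyl in place of trifluoromethoxy, so this further change to the phenyl ring shifts nothing beyond the scatter. The step of a 20-fold higher number from compound 1 to compound 4 (1.30 log units; beyond the scatter) makes a third phenyl-based group that stands far from ethyl, while none of the three stands apart from another. No measurement given here explains this grouping or the gap to ethyl.

On these data alone, the separate shares of the methyl and the trifluoromethyl in compound 4 remain open. Also open, as far as these compounds go, is whether a longer chain such as propyl at this place stays near compound 1, and what an amine or a carboxylic acid on the phenyl ring would do.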